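Notes on a ring exchange at the carbonyl carbon

A few compounds are considered here, and "the series" means these few. Any claim that something is new, unique, unknown or untested is made for them only; others in the source may bear on it.

Values so far in a physicochemical assay for lipophilicity, measured as octanol-water partition, at pH 7.4; on this read-out lower numbers stand for lower lipophilicity and higher numbers for higher lipophilicity:
Compound 1 `O=C(N[C@H]1CN(S(=O)(=O)c2ccccc2)C[C@@H]1C(=O)N[C@H]1CCCNC1)c1cc(-c2ccccc2)on1` gives 1.3
Compound 2 `O=C(N[C@H]1CN(S(=O)(=O)c2ccccc2)C[C@@H]1C(=O)N[C@H]1CCCNC1)c1nnc(-c2ccc(F)cc2)s1` gives 1

Compound 2 (1) lies within the scatter of compound 1 (1.3), so the two values are not separated. The next compound, compound 3 `O=C(N[C@H]1CN(S(=O)(=O)c2ccccc2)C[C@@H]1C(=O)N[C@H]1CCCNC1)c1cc(-c2ccccc2Cl)on1`, is not yet measured. Its change from compound 2 sits on a carbonyl carbon whose other neighbour is an amide-type nitrogen: a group of 12 heavy atoms (9 carbon, 1 nitrogen, 1 oxygen, 1 chlorine; one five-membered aromatic ring with 2 hetero atoms, one six-membered aromatic ring of carbon only) in place of a group of 12 heavy atoms (8 carbon, 2 nitrogen, 1 fluorine, 1 sulfur; one five-membered aromatic ring with 3 hetero atoms, one six-membered aromatic ring of carbon only), on a carbonyl carbon.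

For the measured compounds named here, only one measured step bears on this: a number 0.30 log units lower from compound 1 to compound 2 (within the scatter). It exchanged the same two kinds of five-membered aromatic ring in the opposite sense. Going by the values given here, no measured step covers a chlorine-bearing group. A step upward in this assay is therefore expected, probably larger than that measured one. The estimated step is a number 0.70 log units higher from compound 2 to compound 3 (beyond the scatter). For compound 3 the expected value is 1.7. The estimated range runs from 1.2 to 2.2.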

Compound 3, distribution coefficient: 1.9
For compound 3 the middle estimate is 0.20 log units below the measured one; measured number inside the range.
By their numbers in this assay, from the lowest: compounds 2 and 1 (each within the scatter of the next); then compound 3.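

In this assay, for the compounds shown here, chloro in place of hydrogen on an aromatic carbon gives the first single-substituent comparison, and the result is a number 0.60 log units higher from compound 1 to compound 3 (beyond the scatter) on the shared core. The exchange of groups on the carbonyl carbon can also separate values, with a number 0.90 log units higher from compound 2 to compound 3 (beyond the scatter) where compound 1 and compound 2 remained unseparated, although this step changes the five-membered ring and the substituent on the six-membered ring together. Nothing at hand explains either step.

As far as these compounds go, it remains open whether chloro on the group of compound 2 would give a step of similar size, which would help separate the contributions of the two five-membered rings. From the compounds shown here alone, it is also open how an amine or a methoxy group in place of the chloro would register on this read-out.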